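The source may report more compounds than this note shows. Statements on the series, on what has been measured and on what is new or still open speak of the compounds shown alone.

In a functional assay on A549 cells (Homo sapiens) for cytotoxicity, read by MTT assay, with a stated time of 72 h (on this read-out higher numbers stand for weaker inhibition and lower numbers for stronger inhibition), three esters built on a shared core have been measured. Compound 1 `COc1ccc(C(=O)O[C@H]2CC(C)=C[C@H](O)[C@@]3(C)[C@@H](OC(C)=O)C[C@@](O)(C(C)C)[C@H]23)cc1` gives 79600 nM in this assay. Compound 2 `CC1=CC[C@]2(C)[C@@H]([C@@H](OC(=O)c3ccc(O)cc3)C1)[C@](O)(C(C)C)C[C@@H]2O` gives 83700 nM in this assay, and the number for compound 2 sits together with that of compound 1, the gap between the two lying within the scatter. Compound 3 `C=C1C[C@H](OC(=O)c2ccc(O)cc2)[C@@H]2[C@](C)(CC[C@@]2(O)C(C)C)C[C@@H]1O` does not reach a number in this assay and is reported only as the limit > 100000 nM. That value is the limit of > 100000 nM in this assay, at which 1 of the 3 values shown sits.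

Compound 4 `CC1=CC[C@@]2(C)CC[C@@](O)(C(C)C)[C@@H]2[C@@H](OC(=O)c2ccc(O)cc2)C1` has not yet been measured. It differs from compound 2 in one place: hydrogen in place of hydroxy on a saturated ring carbon. Going by the values given here, no pair of measured compounds separated by a single change is available, so there is nothing to set the size of this step from, and the measured values give no sign that the core tolerates such changes with large shifts in either direction. The step from compound 2 to compound 4 is therefore expected to be a 1.1-fold higher number from compound 2 to compound 4 (0.03 log units; within the scatter), a shift no larger than the scatter. For compound 4 in this assay the estimate is 90000 nM, with a range from 40000 nM to 200000 nM.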

Compound 4, half-maximal inhibitory concentration: > 100000 nM
Compound 4: only a limit was reported; the forecaster's own chance of this, stated with the estimate: 35%; middle value at least 1.1-fold (0.04 log units) away from the limit.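

Hydrogen in place of hydroxy on a saturated ring carbon of the five-membered ring gives the first step on the shared core that can be read across a single change: in this assay it is an at least 1.1-fold higher number from compound 2 to compound 4 (0.07 log units; that floor lies within the scatter). On these data alone, compound 4 gives > 100000 nM, which is a limit and not a number, so this step has only a floor and its full size remains unknown. Compound 4 now stands at the same limit as compound 3: the limit of > 100000 nM in this assay, at which 2 of the 4 values shown sit.

As far as these compounds go, whether the hydroxy on this carbon contributes to the read-out at all stays open, as the floor of the step lies within the scatter. Also open, from the compounds shown here alone, is how an amine or a carboxylic acid on this carbon would read in this assay.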